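Methoxycarbonyl to propoxycarbonyl: working notes on compound 3

This account rests on a few compounds, and the source may have more. Where it says the series, first, only, none or still open, it means among the compounds named here.

Of the compounds shown here, two have been read so far in a functional assay on HepG2 cells (Homo sapiens) for antiproliferative activity, read by MTT assay, with a stated time of 48 h (on this read-out lower numbers stand for stronger inhibition of growth and higher numbers for weaker inhibition of growth), as the test of this series. Compound 1 `CCCOC(=O)N1N=C(c2cccc(OC)c2)CC1c1cc(OC)c(OC)c(OC)c1` gives > 10000 nM as its reading, and this is a limit of the assay and not a number. For the measured compounds named here, compound 2 `COC(=O)N1N=C(c2cccc(O)c2)CC1c1cc(OC)c(OC)c(OC)c1` gives 650 nM as its reading, the only actual number available and so the sole numerical reference point.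

Compound 3 `CCCOC(=O)N1N=C(c2cccc(O)c2)CC1c1cc(OC)c(OC)c(OC)c1` departs from compound 2 in one place: ethyl in place of hydrogen on a saturated chain carbon bound to an oxygen next to a carbonyl group describes the change, ethyl in place of hydrogen on a saturated chain carbon bound to an oxygen next to a carbonyl group, so methoxycarbonyl becomes propoxycarbonyl.

Going by the values given here, no measured pair isolates this change. Compound 1 also carries propoxycarbonyl and reads > 10000 nM as a limit once more. On that thin basis, a moderate loss of growth inhibition is expected in this assay and is likely to exceed the scatter. The estimated change is a 3.8-fold higher number from compound 2 to compound 3 (0.59 log units; beyond the scatter) in the direction of weaker inhibition. For compound 3 the expected value is 2500 nM with an estimated range from 700 nM to 10000 nM in this read-out.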

Compound 3, concentration for 50% growth inhibition: > 10000 nM
Compound 3: a limit, no number; the forecaster's own chance of this, stated with the estimate: 25%; middle value at least 4.0-fold (0.60 log units) from the limit.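

In this assay, the change from methoxycarbonyl to propoxycarbonyl now has a measured pair with the hydroxy-bearing aromatic ring held constant, and it gives an at least 15-fold higher number from compound 2 to compound 3 (1.18 log units; beyond the scatter), a loss of growth inhibition that compound 1 alone could not isolate. Compound 3 gives > 10000 nM, which is a limit of the assay and not a number. The step from compound 1 to compound 3, hydrogen in place of methyl on an oxygen on an aromatic ring, cannot be read, so no effect of that change can be sized with propoxycarbonyl present, and both propoxycarbonyl compounds stand at the same limit: the limit of > 10000 nM in this assay, at which 2 of the 3 values shown sit.

The compounds shown leave open where the loss sets in along the chain, since only methoxycarbonyl and propoxycarbonyl appear here and ethoxycarbonyl would fall on that line. Also open, going by these compounds, is how this assay would read for a carbamoyl group, which carries an amine nitrogen in place of the oxygen next to the carbonyl group, or for a carboxylic acid on a longer chain at this place.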